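The compounds below may be only part of what the source reports. "The series", "measured", "known", "first", "only" and "open" are said of these compounds alone.

Measured compounds, all in a functional assay on MGC-803 cells (Homo sapiens) for cytotoxicity, read by MTT assay, with a stated time of 72 h; on this read-out higher numbers stand for weaker inhibition and lower numbers for stronger inhibition:
- compound 1 `CCNC(=O)N1CCN(C(=S)SCc2cn(Cc3ccc(C)cc3)nn2)CC1` gives 19800 nM
- compound 2 `Cc1ccc(Cn2cc(CSC(=S)N3CCN(C(=O)NC(C)C)CC3)nn2)cc1` gives 16600 nM
- compound 3 `CCNC(=O)N1CCN(C(=S)SCc2cn(Cc3cc(OC)c(OC)c(OC)c3)nn2)CC1` gives 101000 nM

Compound 2 differs from compound 1 by methyl in place of hydrogen on a saturated chain carbon bound to an amide-type nitrogen and a saturated chain carbon. In this assay this change gives a 1.2-fold lower number from compound 1 to compound 2 (0.08 log units; within the scatter), so the two values are treated as equal here. Compound 3 carries a different core; the difference between the core of compound 1 and the core of compound 3 is not broken down here. Compound 3 gives the highest of the three numbers, and its steps to compound 1 and compound 2 are beyond the scatter.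

Compound 4 `COc1cc(Cn2cc(CSC(=S)N3CCN(C(=O)NC(C)C)CC3)nn2)cc(OC)c1OC` is not yet measured. It differs from compound 3 by methyl in place of hydrogen on a saturated chain carbon bound to an amide-type nitrogen and a saturated chain carbon, the same change as that from compound 1 to compound 2, at the same place in words. Because the step of a 1.2-fold lower number from compound 1 to compound 2 (0.08 log units; within the scatter) lay within the scatter, the expectation for compound 4 is a step of a 1.2-fold lower number from compound 3 to compound 4 (0.07 log units; within the scatter), also within the scatter, on the core of compound 3. Compound 4 is therefore expected to give about 85000 nM in this assay, with a range from 40000 nM to 200000 nM.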

Compound 4, half-maximal inhibitory concentration: > 128000 nM
Compound 4 ended at the assay's limit; the forecaster's own chance of this, stated with the estimate: 10%; middle value at least 1.5-fold (0.17 log units) away from the limit.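

In this assay compound 4 reads > 128000 nM, which is a limit of the assay and not a number. On the core of compound 3, the change from ethylcarbamoyl to isopropylcarbamoyl gives an at least 1.2-fold higher number from compound 3 to compound 4 (0.10 log units; that floor lies within the scatter), so this step has a floor but no known size. The series therefore shows no clear gain from this change on either core, but it does not establish whether the change carries over unaltered from one core to the other: the same change on two cores in this assay, a 1.2-fold lower number (0.08 log units; within the scatter) from compound 1 to compound 2 and an at least 1.2-fold higher number (0.10 log units; that floor lies within the scatter) from compound 3 to compound 4; the limit leaves it open whether they differ.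

The true size of the step on the core of compound 3 stays open, and only two cores carrying this change are shown. Also open, on these data alone, is how a longer chain such as butyl, or a chain ending in an amine or a carboxylic acid, would read in place of ethyl or isopropyl on these cores.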